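From acetyl to methylsulfonyl on an amine nitrogen

This account rests on a few compounds, and the source may have more. Where it says the series, first, only, none or still open, it means among the compounds named here.

Of the compounds shown here, three sharing one core have been measured in an ADME assay on HEp-2 cells (Homo sapiens) for cytotoxicity; on this read-out lower numbers stand for higher toxicity in this test and higher numbers for lower toxicity in this test. Compound 1 `CC(C)CCn1c(Cn2c(=O)n(C(C)C)c3ccccc32)nc2cc(CN)ccc21`, which carries a free amino group, gives 3920 nM, and its dimethylamino counterpart, compound 2 `CC(C)CCn1c(Cn2c(=O)n(C(C)C)c3ccccc32)nc2cc(CN(C)C)ccc21`, gives 5650 nM. Compound 3 `CC(=O)NCc1ccc2c(c1)nc(Cn1c(=O)n(C(C)C)c3ccccc31)n2CCC(C)C`, the acetamido member, gives 178000 nM, the highest number of the three and clearly separated from both others.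

Compound 4 `CC(C)CCn1c(Cn2c(=O)n(C(C)C)c3ccccc32)nc2cc(CNS(C)(=O)=O)ccc21` has methylsulfonyl in place of acetyl on an amine nitrogen.

Going by the values given here, no measured step makes this exchange, so the evidence is indirect. Dimethylamino in place of amino gave a 1.4-fold higher number from compound 1 to compound 2 (0.16 log units; within the scatter), a step within the scatter. Acetyl in place of hydrogen on the amine nitrogen gave a 45-fold higher number from compound 1 to compound 3 (1.66 log units; beyond the scatter), and acetamido in place of dimethylamino gave a 32-fold higher number from compound 2 to compound 3 (1.50 log units; beyond the scatter). Both large steps end at compound 3, and compound 4 differs from it only in the group on that same nitrogen. If methylsulfonyl acts as a close replacement for acetyl, the number should stay in the range of compound 3 rather than return towards those of the two amines. The expected step is a 1.2-fold lower number from compound 3 to compound 4 (0.07 log units; within the scatter), an estimate of no change beyond the scatter. For compound 4 the estimated value is 150000 nM, with an expected range of 50000 nM to 400000 nM.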

Compound 4, half-maximal cytotoxic concentration: 30800 nM
Compound 4: middle estimate off by 4.9-fold (0.69 log units), on the high side; the measured number lies below the stated range.
By their numbers in this assay, from the lowest: compounds 1 and 2 (each within the scatter of the next); then compound 4; then compound 3.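

In this assay, the two groups on this amine nitrogen are not interchangeable: the exchange of acetyl for methylsulfonyl gives a 5.8-fold lower number from compound 3 to compound 4 (0.76 log units; beyond the scatter), so the large gain seen with acetyl is only partly kept. Compound 4 still stands clearly apart from both amines, with methylsulfonyl in place of hydrogen giving a 7.9-fold higher number from compound 1 to compound 4 (0.90 log units; beyond the scatter) and methanesulfonamido in place of dimethylamino giving a 5.5-fold higher number from compound 2 to compound 4 (0.74 log units; beyond the scatter), so substitution on this nitrogen can raise the number without reaching the level of compound 3. No measurement given here accounts for the difference between the acetyl and methylsulfonyl groups.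

On these data alone, with only these two groups on the nitrogen, it remains open where a urea, a methyl carbamate or a longer acyl chain such as propanoyl would fall relative to compound 3 and compound 4. As far as these compounds go, it also remains open whether a longer sulfonyl group such as ethylsulfonyl would follow methylsulfonyl, and whether the same order would hold on a different core.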